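One Substituent Swap on a Saturated Ring Carbon

The compounds below may be only part of what the source reports. "The series", "measured", "known", "first", "only" and "open" are said of these compounds alone.

Compound 1, `CC(C(=O)NCc1ccc(C(F)(F)F)nc1N1CCC(C)(C)CC1)c1ccc(NS(C)(=O)=O)c(F)c1`: 0.3 nM
Compound 2, `CC(C(=O)NCc1ccc(C(F)(F)F)nc1N1CCC(C(F)(F)F)CC1)c1ccc(NS(C)(=O)=O)c(F)c1`: 0.6 nM

In a functional assay on CHO-K1 cells for antagonist activity at transient receptor potential cation channel subfamily V member 1 (Homo sapiens), read by FLIPR (on this read-out lower numbers stand for stronger inhibition and higher numbers for weaker inhibition), compound 1 gives 0.3 nM, and compound 2 gives 0.6 nM. For the measured compounds named here, compound 2 has the higher of the two numbers, yet the only step, a 2.0-fold higher number from compound 1 to compound 2 (0.30 log units; within the scatter), lies within the scatter, so the two compounds cannot be told apart. Compound 3, `CC(C(=O)NCc1ccc(C(F)(F)F)nc1N1CCC(OC(=O)C(C)(C)C)CC1)c1ccc(NS(C)(=O)=O)c(F)c1`, is not yet measured; it differs from compound 2 by ((tert-butyl)carbonyl)oxy in place of trifluoromethyl on a saturated ring carbon. The single step from compound 1 to compound 2 changed the same ring carbon and stayed within the scatter, so no direction is shown, though the entering group is larger than in that step. Compound 3 is expected to give 1.5 nM in this assay, in the range 0.4 nM to 6 nM, an expected step of a 2.5-fold higher number from compound 2 to compound 3 (0.40 log units; beyond the scatter).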

Compound 3, inhibition constant: 2 nM
The estimate for compound 3 lay 1.3-fold (0.12 log units) below the measured number, and the stated range covers the measured number.
By their numbers in this assay, from the lowest: compounds 1 and 2 (each within the scatter of the next); then compound 3.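

In this assay, ((tert-butyl)carbonyl)oxy in place of trifluoromethyl gives a 3.3-fold higher number from compound 2 to compound 3 (0.52 log units; beyond the scatter) and is the only step shown at this saturated ring carbon that lies beyond the scatter. The number at this position can therefore depend on the group it carries, though this step is modest and compound 3 still gives 2 nM in the low nanomolar range. Nothing measured here explains the higher number.

On these data alone, both the heavy-atom count and the carbonyl change in this one step, so their separate contributions stay open. As far as these compounds go, how an amine or a carboxylic acid on this ring carbon would read also remains open.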